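The compounds below may be only part of what the source reports. "The series", "measured", "known", "first", "only" and "open" are said of these compounds alone.

Compound 1 `Cc1ccc(Nc2nccc(-c3ccnc4ccccc34)n2)cc1` gives the highest number of the three compounds measured in a functional assay on SK-LU-1 cells (Homo sapiens) for cytotoxicity, read by sulforhodamine B assay, with a stated time of 48 h, tested at 50 uM (a lower number here means less inhibition, a higher number more inhibition at the concentration tested (going by the name of the read-out)), where compound 1 reaches 100%. Compound 2 `Nc1nccc(-c2ccnc3ccccc23)n1` gives 78.2%, and compound 3 `Nc1nccc(-c2cnc3ccccc3c2)n1` gives 59.3%. Among the measured compounds shown here, the only measured single change is a number 21.8 percentage points lower from compound 1 to compound 2 (beyond the scatter), a modest loss when the whole 4-methylphenyl is swapped for hydrogen. Compound 4 `FC(F)(F)c1ccc(Nc2nccc(-c3ccnc4ccccc34)n2)cc1` keeps that group and differs from compound 1 only by trifluoromethyl in place of methyl on an aromatic carbon. For the measured compounds named here, no measured step touches the methyl itself, so the step from compound 1 to compound 2 is only a loose guide, showing that the group matters without telling what its substituent does. With compound 1 already at the top of the scale, the expected step is a number 5 percentage points lower from compound 1 to compound 4 (within the scatter), none beyond the scatter. Compound 4 is therefore estimated at 95%, within 80% to 100%.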

Compound 4, a percentage reported as inhibition, at one concentration (the size of the read-out at that concentration, not a potency): 100%
The estimate for compound 4 lay 5 percentage points below the measured number; the measured number falls inside the stated range.
By their numbers in this assay, from the lowest: compound 3; then compound 2; then compounds 1 and 4 (each within the scatter of the next).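

Trifluoromethyl in place of methyl gives no change at the digits printed from compound 1 to compound 4 (within the scatter) in this assay, so the earlier finding that the whole 4-methylphenyl matters can now be narrowed: at this position, the larger group is accepted without a visible loss at the concentration tested. Both compounds sit at the top of the scale, so any difference in strength beyond it cannot be seen here. No measured evidence explains this result.

On these data alone, whether an amine, a methoxy group or a chlorine at this position would keep the number that high remains open.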